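A few compounds are considered here, and "the series" means these few. Any claim that something is new, unique, unknown or untested is made for them only; others in the source may bear on it.

Measured in a functional assay on A549 cells (Homo sapiens) for cytotoxicity, read by MTT assay, with a stated time of 72 h; a lower number here means a stronger inhibitor, a higher number a weaker inhibitor:

- Compound 1 `O=S(=O)(c1ccc(Br)cc1)c1nc2ccccc2nc1N1CCCC1`: > 50000 nM
- Compound 2 `COc1ccc(S(=O)(=O)c2nc3ccccc3nc2N2CCc3ccccc3C2)cc1`: > 50000 nM
- Compound 3 `O=S(=O)(c1ccc(Br)cc1)c1nc2ccccc2nc1N1CCc2ccccc2C1`: not yet measured

Compound 2 reads > 50000 nM in this assay, and this is a limit of the assay, not a number. Compound 1 reads > 50000 nM, which is a limit as well. The whole record so far is therefore (the limit of > 50000 nM in this assay, at which 2 of the 2 values shown sit). Going by the values given here, neither compound has a true number, and no step between two measured compounds is available to show how large a single change can be here.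

Compound 3 differs from compound 2 in one place: bromo in place of methoxy on an aromatic carbon. In words, this is bromo in place of methoxy on an aromatic carbon, para to a large group, turning 4-methoxyphenyl into 4-bromophenyl. Compound 1 also carries a 4-bromophenyl and gives no number either. No step beyond the scatter is therefore expected in this assay, and a reading at the limit again is the likeliest outcome. The estimated step is a number no higher from compound 2 to compound 3 (the limit leaves the size open). For compound 3 the expected value is 50000 nM, with an estimated range of 20000 nM to 80000 nM.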

Compound 3, half-maximal inhibitory concentration: > 50000 nM
Compound 3: a limit, no number (the forecaster's own chance of this, stated with the estimate: 75%); the middle value lies on the limit itself.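

In this assay, compound 3 gives > 50000 nM, which is a limit and not a number. No step can be read from compound 2 to compound 3 or from compound 1 to compound 3, as all three compounds share one reading: the limit of > 50000 nM in this assay, at which 3 of the 3 values shown sit. The compounds shown leave open whether swapping methoxy for bromo, or pyrrolidin-1-yl for 1,2,3,4-tetrahydroisoquinolin-2-yl, changes cytotoxicity at all.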